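Working notes: from compound 2 to compound 3

The source may hold more compounds than are shown below. What is called first, only, known or untested is meant among the compounds shown, and "the series" means these compounds.

Measured in a functional assay on HCT-116 cells (Homo sapiens) for inhibition, read by resazurin assay, with a stated time of 5 days (a lower number here means a stronger inhibitor of growth, a higher number a weaker inhibitor of growth), so far:
- compound 1 `O=C(CCCC1CCN(S(=O)(=O)c2ccccc2)CC1)NO` gives 2700 nM
- compound 2 `Cc1cc(C)cc(S(=O)(=O)N2CCC(CCCC(=O)NO)CC2)c1` gives "not determined" (no result reported)

Compound 2 has no number in this assay, so it offers no reference point, and compound 1 alone carries a value. Compound 3 `O=C(CCCC1CCN(S(=O)(=O)Nc2ccccc2)CC1)NO` is still unmeasured. The structural change is anilino in place of 3,5-dimethylphenyl on a sulfonyl sulfur, with anilino in place of 3,5-dimethylphenyl on a sulfonyl sulfur. Within the data shown here, no step between measured compounds exists, so no shift is expected from compound 1 (2700 nM) in either direction. Compound 3 is expected at 2500 nM with an estimated range of 800 nM to 8000 nM in this assay as the read-out.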

Compound 3, concentration for 50% growth inhibition: 2000 nM
The estimate for compound 3 lay 1.3-fold (0.10 log units) above the measured number; the measured number falls inside the stated range.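

In this assay, among these compounds, anilino in place of phenyl on a sulfonyl sulfur gives a 1.4-fold lower number from compound 1 to compound 3 (0.13 log units; within the scatter), the first readable step at this position. The change from phenyl to anilino therefore leaves growth inhibition within the usual scatter, so the two groups cannot be separated in this read-out. Nothing available accounts for this result.

Steps involving compound 2 cannot be read, so the 3,5-dimethylphenyl group remains uncompared at this position. From the compounds shown here alone, how a benzyl or a methylamino group on the sulfonyl sulfur would read also remains open.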